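The compounds below may be only part of what the source reports. "The series", "measured", "known", "first", "only" and "open" are said of these compounds alone.

Compound 1 `NNC(=O)CCc1ccncc1-c1ccc2ccccc2c1` gives 102% in an assay on a protein complex for inhibition of CDK8/Cyclin C (Homo sapiens), with a stated time of 1 h, tested at 10 uM; a lower number here means less inhibition, a higher number more inhibition at the concentration tested (going by the name of the read-out). Compound 2 `NNC(=O)COc1ccncc1-c1ccc2ccccc2c1` gives 19%. Compound 3 `CCOC(=O)/C=C/c1ccncc1-c1ccc2ccccc2c1` gives 102%.

Compound 3 stands level with compound 1, the two together the highest of the three numbers, while a number 83 percentage points higher from compound 2 to compound 3 (beyond the scatter) and no change at the digits printed from compound 1 to compound 3 (within the scatter). Compound 4 `O=C(O)CCNC(=O)/C=C/c1ccncc1-c1ccc2ccccc2c1` differs from compound 3 by (2-carboxyethyl)amino in place of ethoxy on a carbonyl carbon. Among the measured compounds shown here, no measured step alters the ester end of the chain; the steps that exist swap the whole group on the aromatic carbon, so they do not bear directly on this change. With the chain and the shared core retained, compound 4 is expected to keep most of the inhibition of compound 3, with a number 12 percentage points lower from compound 3 to compound 4 (beyond the scatter) expected to stay within the scatter. Compound 4 is therefore estimated at 90%, with a range of 55% to 105%.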

Compound 4, a percentage reported as inhibition, at one concentration (the size of the read-out at that concentration, not a potency): 91%
Beside the measured number, compound 4's estimate is 1 percentage points below it; the measured number falls inside the stated range.
By their numbers in this assay, from the lowest: compound 2; then compound 4; then compounds 1 and 3 (each within the scatter of the next).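

Replacing ethoxy with (2-carboxyethyl)amino on the carbonyl carbon gives a number 11 percentage points lower from compound 3 to compound 4 (beyond the scatter) in this assay, a modest step, so most of the inhibition survives a larger group with more hydrogen-bond donors at this end of the chain. The earlier steps shown here swapped the whole group on the aromatic carbon, and only this one reads the carbonyl end alone. Nothing at hand explains the size of this step.

Which part of the new group carries the small loss stays open. A plain ethylamino group, a free carboxylic acid on the carbonyl carbon, or a longer chain ending in an amine would help to separate this.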